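Swapping a bromomethyl aryl group for a fluoro-methyl aryl group

A few compounds are considered here, and "the series" means these few. Any claim that something is new, unique, unknown or untested is made for them only; others in the source may bear on it.

Measured so far:
Compound 1, `CCC1=C(O)c2c(oc(-c3ccc(C(C)C)cc3)cc2=O)C(CC)(CC)C1=O`, 1.08 uM
Compound 2, `CCOc1ccc(-c2cc(=O)c3c(o2)C(CC)(CC)C(=O)C(CC)=C3O)cc1`, 7.54 uM
Compound 3, `CCC1=C(O)c2c(oc(-c3ccc(CBr)cc3)cc2=O)C(CC)(CC)C1=O`, 27.9 uM

In a functional assay on KBVIN cells (Homo sapiens) for antiproliferative activity, read by sulforhodamine B assay, with a stated time of 3 days (on this read-out higher numbers stand for an effect only at larger amounts of compound and lower numbers for an effect already at smaller amounts), compound 3 stands at the highest number of the three. Its nearest neighbour is compound 2, separated by a 3.7-fold higher number from compound 2 to compound 3 (0.57 log units; beyond the scatter), and the furthest is compound 1, separated by a 26-fold higher number from compound 1 to compound 3 (1.41 log units; beyond the scatter). Both of these steps lie beyond the scatter, so compound 3 is the least active of the set on this read-out.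

Compound 4, `CCC1=C(O)c2c(oc(-c3ccc(C)c(F)c3)cc2=O)C(CC)(CC)C1=O`, is the next compound to be measured. It differs from compound 3 by 3-fluoro-4-methylphenyl in place of 4-(bromomethyl)phenyl on an aromatic carbon.

Within the data shown here, two measured steps bear on this change, since both end in the bromomethyl group that now leaves: a 26-fold higher number from compound 1 to compound 3 (1.41 log units; beyond the scatter) and a 3.7-fold higher number from compound 2 to compound 3 (0.57 log units; beyond the scatter). In both cases the bromomethyl group went with a clearly higher number, so its removal is expected to move the number downward. The entering 3-fluoro-4-methylphenyl group is neither the isopropyl of compound 1 nor the ethoxy of compound 2, so the size of the move is uncertain and is estimated to fall between those two steps.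

The expected result is a step of an 8.0-fold lower number from compound 3 to compound 4 (0.90 log units; beyond the scatter). Compound 4 is therefore estimated at 3.5 uM, with a range from 1 uM to 12 uM.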

Compound 4, concentration for half-maximal effect: 2.95 uM
The estimate for compound 4 lay 1.2-fold (0.07 log units) above the measured number; low and high end bracket the measured number.
By their numbers in this assay, from the lowest: compound 1; then compound 4; then compound 2; then compound 3.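

In this assay, the exchange of 4-(bromomethyl)phenyl for 3-fluoro-4-methylphenyl gives a 9.5-fold lower number from compound 3 to compound 4 (0.98 log units; beyond the scatter) even though the computed heavy-atom count, ring type and hydrogen-bond counts of the two groups match, so a difference these counts do not capture is enough to move the number at this position. The new group also falls within the range set by the earlier aryl groups: it gives a 2.6-fold lower number from compound 2 to compound 4 (0.41 log units; beyond the scatter) and, against the best of the four, a 2.7-fold higher number from compound 1 to compound 4 (0.44 log units; beyond the scatter), so compound 1 keeps the lowest number and the four aryl groups occupy distinct levels, each step beyond the usual scatter. No measurement at hand accounts for any of these differences.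

Compound 4 carries its fluorine and its methyl together, so the compounds shown do not tell how much each contributes, nor how 4-methylphenyl without the fluorine would stand. They also leave open how an aryl group bearing an amine or a carboxylic acid would compare with 4-isopropylphenyl at this position.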